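Ester chain shortening from compound 2 to compound 4

The compounds below may be only part of what the source reports. "The series", "measured", "known", "first", "only" and "open" are said of these compounds alone.

Three compounds have numbers in a functional assay on PC-3 cells (Homo sapiens) for cytotoxicity, read by MTT assay, with a stated time of 72 h; a lower number here means a stronger inhibitor of growth, a higher number a weaker inhibitor of growth. Compound 1 `CC(C)COC(=O)Nc1ccc([Se][Se]c2ccc(NC(=O)OCC(C)C)cc2)cc1` gives 48900 nM; compound 2 `CC(C)COC(=O)Nc1ccc([Se]C#N)cc1` gives 47300 nM; compound 3 `CCCCCCOC(=O)Nc1ccc([Se][Se]c2ccc(NC(=O)OCCCCCC)cc2)cc1` gives 25700 nM. Compound 2 stands second highest of the three numbers, within the scatter of compound 1 and also of compound 3, so no order among them is drawn. Compound 4 `CCOC(=O)Nc1ccc([Se]C#N)cc1` is not yet measured; it differs from compound 2 by methyl in place of isopropyl on a saturated chain carbon bound to an oxygen next to a carbonyl group. For the measured compounds named here, no measured pair shows this change, so the step has no precedent here. For compound 4 the expectation in this assay is a step of no more than the scatter, with no direction favoured. Compound 4 is expected at 47000 nM, in the range 20000 nM to 110000 nM, meaning an expected step of a 1.0-fold lower number from compound 2 to compound 4 (0.00 log units; within the scatter).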

Compound 4, concentration for total growth inhibition: 39200 nM
Compound 4: middle estimate off by 1.2-fold (0.08 log units), on the high side; measured number inside the range.
By their numbers in this assay, from the lowest: compounds 3, 4, 2 and 1 (each within the scatter of the next).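

In this assay the series now has its first step in one place, and a 1.2-fold lower number from compound 2 to compound 4 (0.08 log units; within the scatter) puts a size on methyl in place of isopropyl on a saturated chain carbon bound to an oxygen next to a carbonyl group. On the core of compound 2, isobutoxy to ethoxy therefore stays within the scatter. No measurement at hand bears on the reason for this step.

The compounds shown leave open whether a longer chain, or a chain carrying an amine or a carboxylic acid, at this position on the same core would give a step beyond the scatter.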